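The source may report more compounds than this note shows. Statements on the series, on what has been measured and on what is new or still open speak of the compounds shown alone.

Measured in an ADME assay on HEK-293T cells (Homo sapiens) for cytotoxicity, read by MTT assay, with a stated time of 48 h (on this read-out lower numbers stand for higher toxicity in this test and higher numbers for lower toxicity in this test), each value a limit:
Compound 1 `Cn1cc(C2CC(c3ccccc3)=NN2C(=O)c2cccnc2Cl)c2ccccc21`: > 300000 nM
Compound 2 `COc1ccc2c(c1)c(C1CC(c3ccccc3)=NN1C(=O)c1cccnc1)cn2C`: > 300000 nM
Compound 3 `COc1ccc2c(c1)c(C1CC(c3ccccc3)=NN1C(=O)c1ccc(OC)nc1)cn2C`: > 300000 nM

Compound 3 gives only a limit, > 300000 nM, and not a number. Compound 4 `COc1ccc2c(c1)c(C1CC(c3cc(OC)c(OC)c(OC)c3)=NN1C(=O)c1ccc(OC)nc1)cn2C` differs from it as follows: 3,4,5-trimethoxyphenyl in place of phenyl on a carbon with a double bond to nitrogen. Thus 3,4,5-trimethoxyphenyl stands in place of phenyl on a carbon with a double bond to nitrogen. Among the measured compounds shown here, the only measured step, a step that the two limits leave unreadable from compound 2 to compound 3, is a different change and offers no size to carry over. No step beyond the scatter, in either direction, is therefore expected in this assay because the limit of > 300000 nM in this assay, at which 3 of the 3 values shown sit, is all the data show. The estimated a number no higher from compound 3 to compound 4 (the limit leaves the size open) reflects this expectation. Compound 4 is expected to give about 300000 nM, with an estimated range of 100000 nM to 500000 nM.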

Compound 4, half-maximal cytotoxic concentration: > 300000 nM
Compound 4 gave a limit, no number (the forecaster's own chance of this, stated with the estimate: 65%); the middle value sits exactly at the limit.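

Neither compound 3 nor compound 4 gives a number in this assay, so no step can be read between them: the limit of > 300000 nM in this assay, at which 4 of the 4 values shown sit.

The compounds shown leave open what 3,4,5-trimethoxyphenyl in place of phenyl does to the half-maximal cytotoxic concentration.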